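Amide series: free amine in place of protected amine

A few compounds are considered here, and "the series" means these few. Any claim that something is new, unique, unknown or untested is made for them only; others in the source may bear on it.

Measured so far in a functional assay on PANC-1 cells (Homo sapiens) for inhibition, read by MTT assay, with a stated time of 72 h; on this read-out higher numbers stand for weaker inhibition and lower numbers for stronger inhibition:
Compound 1 `O=C(Nc1cccc2cccnc12)c1ncccn1` gives only the limit > 10000 nM.
Compound 2 `O=C(Nc1cc(Cl)cc2cccnc12)c1ncccn1` gives 4670 nM.
Compound 3 `CC(C)(C)OC(=O)NCCOc1cc(NC(=O)c2ncccn2)c2ncccc2c1` gives only the limit > 10000 nM.

Among the compounds with values here, the one measured step is an at least 2.1-fold lower number from compound 1 to compound 2 (0.33 log units; beyond the scatter). Compound 3 stands at the upper limit of this assay, which is the same limit (the limit of > 10000 nM in this assay, at which 2 of the 3 values shown sit).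

Compound 4 `NCCOc1cc(NC(=O)c2ncccn2)c2ncccc2c1` differs from compound 3 by hydrogen in place of tert-butoxycarbonyl on an amine nitrogen. Within the data shown here, the measured step concerns a chloro substituent on the aromatic ring and does not bear on this change; no measured pair shows a protected amine against a free one. The expected step is therefore an at least 1.2-fold lower number from compound 3 to compound 4 (0.09 log units; that floor lies within the scatter), with no clear direction. Compound 4 is estimated at 8000 nM, within 2000 nM to 30000 nM.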

Compound 4, half-maximal inhibitory concentration: > 10000 nM
Compound 4 gave a limit, no number; the forecaster's own chance of this, stated with the estimate: 55%; middle value at least 1.2-fold (0.09 log units) away from the limit.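

Within the data shown here, with 2-aminoethoxy in place of chloro on an aromatic carbon, this assay shows an at least 2.1-fold higher number from compound 2 to compound 4 (0.33 log units; beyond the scatter), so a chloro-bearing compound, compound 2, remains the only one here with a number. The steps from compound 3 and from compound 1 to compound 4 cannot be read, so removing tert-butoxycarbonyl has no measurable effect to report. Compound 4 gives only a limit, as do compound 3 and compound 1: the limit of > 10000 nM in this assay, at which 3 of the 4 values shown sit.

On these data alone, whether a longer chain ending in an amine would reach a number remains open. So does whether a carboxylic acid in place of the amine would.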